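The source may hold more compounds than are shown below. What is called first, only, known or untested is meant among the compounds shown, and "the series" means these compounds.

In a functional assay on MCF7 cells (Homo sapiens) for antiproliferative activity, read by MTT assay, with a stated time of 48 h (on this read-out higher numbers stand for weaker inhibition and lower numbers for stronger inhibition), compound 1 (`CC(C)=CCC[C@]1(C)/C=C/[C@@H](OC(=O)C=C(C)C)[C@](C)(O)/C=C/C(=O)/C(CN2CCN(C)CC2)=C\C1`) gives 550 nM and compound 2 (`COCOC/C1=C/C[C@](C)(CCC=C(C)C)/C=C/[C@@H](OC(=O)C=C(C)C)[C@](C)(O)/C=C/C1=O`) gives 3120 nM, the higher of the two numbers and thus the weaker inhibition. Compound 3 (`CO/N=C/C1=C/C[C@](C)(CCC=C(C)C)/C=C/[C@@H](OC(=O)C=C(C)C)[C@](C)(O)/C=C/C1=O`) differs from compound 2 in one place: a group of 4 heavy atoms (2 carbon, 1 nitrogen, 1 oxygen; no ring) in place of a group of 5 heavy atoms (3 carbon, 2 oxygen; no ring), on a double-bonded ring carbon, on a double-bonded ring carbon of the shared core. Within the data shown here, one measured step bears on this, the modest 5.7-fold higher number from compound 1 to compound 2 (0.75 log units; beyond the scatter), which lies beyond the scatter and was made on the saturated chain carbon bound to a double-bonded ring carbon. Among the measured compounds shown here, no measured compound carries the entering group, so the direction is uncertain. In this assay, a step smaller than that one is expected, leaning towards a lower number and probably within the scatter. The expected value for compound 3 is 2000 nM, with an estimated range of 700 nM to 5500 nM. The estimated change is a 1.6-fold lower number from compound 2 to compound 3 (0.19 log units; within the scatter).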

Compound 3, half-maximal inhibitory concentration: 2510 nM
Compound 3: middle estimate off by 1.3-fold (0.10 log units), on the low side; low and high end bracket the measured number.
By their numbers in this assay, from the lowest: compound 1; then compounds 3 and 2 (each within the scatter of the next).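

In this assay, the exchange on the double-bonded ring carbon gives a 1.2-fold lower number from compound 2 to compound 3 (0.09 log units; within the scatter), so the group entering in compound 3 and the (methoxymethoxy)methyl group it replaces, neither with a ring, cannot be told apart here. Compound 1 stays separate from both: the step to compound 3 is a 4.6-fold higher number from compound 1 to compound 3 (0.66 log units; beyond the scatter), which is close in size to a 5.7-fold higher number from compound 1 to compound 2 (0.75 log units; beyond the scatter), and among these three compounds only the one carrying 4-methylpiperazin-1-yl gives the lower number, with none going against this. Nothing available explains these numbers.

The compounds shown leave open whether the lower number of compound 1 depends on the whole six-membered ring or on an amine alone. A morpholine, a dimethylamino group or a carboxylic acid on the same saturated chain carbon would help to separate these readings.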